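Swapping the aryl group on the sulfonyl sulfur of compound 2

This account rests on a few compounds, and the source may have more. Where it says the series, first, only, none or still open, it means among the compounds named here.

Measured compounds and their values in an assay on isolated protein for displacement of a labelled ligand from metabotropic glutamate receptor 5 (Homo sapiens), with a stated time of 60 min, tested at 1 uM; a lower number here means less inhibition, a higher number more inhibition at the concentration tested (going by the name of the read-out):
compound 1 `CC1CCN(c2c(S(=O)(=O)c3cc(Cl)cc(Cl)c3)cnc3ccc(F)cc23)CC1` gives 69%;
compound 2 `Cc1cc(C)cc(S(=O)(=O)c2cnc3cc(F)ccc3c2N2CCC(C)CC2)c1` gives 80%;
compound 3 `CC1CCN(c2c(S(=O)(=O)c3ccc(Cl)cc3)cnc3ccc(F)cc23)CC1` gives 80%.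

Compound 2 stands level with compound 3 at the digits shown, and the two of them give the highest numbers of the three. Compound 1 sits below, the gap to compound 2 being beyond the scatter.

Compound 4 `CC1CCN(c2c(S(=O)(=O)c3ccc(F)cc3)cnc3cc(F)ccc23)CC1` has not yet been tested in this assay. It differs from compound 2 in one place: 4-fluorophenyl in place of 3,5-dimethylphenyl on a sulfonyl sulfur.

Going by the values given here, one measured step bears on this: a number 11 percentage points higher from compound 1 to compound 3 (beyond the scatter). That step also removes two substituents from the aryl ring on the sulfonyl sulfur and puts a single halogen in their place, and it raised the number by a modest amount. Compound 2 already stands at the top of the present set, so the room to rise is limited, and the entering group here is a fluorine rather than a chlorine.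

For compound 4 the expected value is 76% (range 55% to 92%), which means an expected step of a number 4 percentage points lower from compound 2 to compound 4 (within the scatter), within the scatter.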

Compound 4, a percentage reported as inhibition, at one concentration (the size of the read-out at that concentration, not a potency): 74.5%
Estimate against measurement, compound 4: 1.5 percentage points above; measured number inside the range.
By their numbers in this assay, from the lowest: compounds 1, 4, 2 and 3 (each within the scatter of the next, the first and the last beyond it).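

In this assay, the change on the sulfonyl sulfur reads a number 5.5 percentage points lower from compound 2 to compound 4 (within the scatter), so this assay cannot separate 4-fluorophenyl from 3,5-dimethylphenyl at this place. The earlier step at this place swapped one chlorine-bearing aryl group for another, whereas this one shows that the two methyl groups can give way to a single fluorine on the core of compound 2 without a change beyond the scatter. The compounds shown offer no measurement that would explain this result.

As far as these compounds go, whether the 4-chlorophenyl group of compound 3 would behave like 4-fluorophenyl on the core of compound 2 remains open. So does the effect of an amine or a carboxylic acid on the aryl ring attached to the sulfonyl sulfur.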